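The compounds below may be only part of what the source reports. "The series", "measured", "known", "first", "only" and "open" are said of these compounds alone.

Measured so far in an ADME assay on MT4 cells (Homo sapiens) for cytotoxicity, read by MTT assay; a higher number here means that more compound is tolerated, a lower number that less compound is tolerated:
- compound 1 `O=C1c2ccccc2C(=O)N1CCOC(=S)N(C(=O)c1ccccc1[N+](=O)[O-])c1ccc(Cl)cc1`: 21000 nM
- compound 2 `O=C1c2ccccc2C(=O)N1CCOC(=S)N(C(=O)c1cccnc1Cl)c1ccc(Br)cc1`: > 100000 nM
- compound 3 `O=C1c2ccccc2C(=O)N1CCOC(=S)N(C(=O)c1ccc(Cl)c([N+](=O)[O-])c1)c1ccccc1`: 51000 nM

Compound 1 stands at the lowest of the two numbers in this assay; its nearest neighbour is compound 3, which sits at a higher value, a gap beyond the scatter. Compound 2 gives no number in this assay, only a limit (the limit of > 100000 nM in this assay, at which 1 of the 3 values shown sits), so compound 2 cannot be placed against compound 1 or compound 3 beyond saying that it tolerates more compound than either.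

The next compound is compound 4 `O=C1c2ccccc2C(=O)N1CCOC(=S)N(C(=O)c1ccc(Cl)cc1Cl)c1ccc(Cl)cc1`. It differs from compound 1 in one place: 2,4-dichlorophenyl in place of 2-nitrophenyl on a carbonyl carbon. Among the compounds with values here, no step between two measured compounds repeats this change, so nothing measured here fixes its size or direction. The three measured values span a range that is only partly beyond the scatter, and the two numbers lie within a modest gap of each other.

On this basis a small step is expected, of the order of the scatter, with no firm direction. The step from compound 1 to compound 4 is estimated as a 1.2-fold higher number from compound 1 to compound 4 (0.09 log units; within the scatter). For compound 4 the estimated value in this assay is 26000 nM, with a range from 10000 nM to 70000 nM.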

Compound 4, half-maximal cytotoxic concentration: 18000 nM
For compound 4 the middle estimate is 1.4-fold (0.16 log units) above the measured one, within the range that was stated.
By their numbers in this assay, from the lowest: compounds 4 and 1 (each within the scatter of the next); then compound 3. At a limit, above all of these: compound 2.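

At the carbonyl carbon, with the rest of the core of compound 1 held constant, this assay now gives a first readable step: a 1.2-fold lower number from compound 1 to compound 4 (0.07 log units; within the scatter). The 2-nitrophenyl group of compound 1 and the 2,4-dichlorophenyl group of compound 4 cannot be told apart in this read-out, so a nitro group is not needed at this position for cytotoxicity in this range, and a group counted with no hydrogen-bond acceptors gives a value within the scatter of one counted with two. Nothing to hand accounts for this outcome or explains why these two groups match.

Compound 2 and compound 3 each differ from compound 1 and from compound 4 in more than one place, so steps to them cannot be read, and this single pair does not show whether the match holds when the 4-chlorophenyl group on the nitrogen is replaced. Also open, from the compounds shown here alone, is how this carbonyl position would respond to an aryl group carrying an amine or a carboxylic acid, or to a longer alkyl chain in place of the aromatic ring.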